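A few compounds are considered here, and "the series" means these few. Any claim that something is new, unique, unknown or untested is made for them only; others in the source may bear on it.

Among the compounds with values here, compound 2 `Cc1cc(C(=O)O)c(C)n1-c1cccc(C(C)(C)C)c1` gives 460 nM in an assay on cells for inhibition of Palmitoleoyl-protein carboxylesterase NOTUM variant C330S (Homo sapiens), read by fluorescence, with a stated time of 40 min (on this read-out lower numbers stand for stronger inhibition and higher numbers for weaker inhibition), the lowest of the two numbers so far. Compound 1 `Cc1cc(C(=O)O)c(C)n1-c1cccc(C(F)(F)F)c1` gives 1500 nM in this assay. Within the data shown here, the only measured step is a 3.3-fold lower number from compound 1 to compound 2 (0.51 log units; beyond the scatter), a modest gain on moving from trifluoromethyl to tert-butyl at this position. Compound 3 `Cc1cc(C(=O)O)c(C)n1-c1cccc(C#N)c1` carries cyano in place of tert-butyl on an aromatic carbon. Among the measured compounds shown here, no measured compound bears cyano, so the step is read against compound 1, whose 1500 nM marks the number for a non-alkyl group there. Compound 3 is therefore expected to give a higher number than compound 2, a 4.3-fold higher number from compound 2 to compound 3 (0.64 log units; beyond the scatter), estimated at 2000 nM with a range of 600 nM to 7000 nM.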

Compound 3, half-maximal inhibitory concentration: 3100 nM
Estimate against measurement, compound 3: 1.6-fold (0.19 log units) below; low and high end bracket the measured number.
By their numbers in this assay, from the lowest: compound 2; then compound 1; then compound 3.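

In this assay, cyano in place of tert-butyl gives a 6.7-fold higher number from compound 2 to compound 3 (0.83 log units; beyond the scatter) and so gives up the gain seen with tert-butyl. Cyano in place of trifluoromethyl gives a 2.1-fold higher number from compound 1 to compound 3 (0.32 log units; beyond the scatter) and places cyano last of the three groups at this position, in the order tert-butyl, trifluoromethyl, cyano. Nothing measured here accounts for this order. Open, going by these compounds, is whether an amine, a methoxy group or a carboxylic acid at this position would fit that order. Also open, on these data alone, is whether a longer alkyl chain would give a lower number than tert-butyl.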